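Phenylethynyl for fluorophenyl at the pyridine-side position

The source may hold more compounds than are shown below. What is called first, only, known or untested is meant among the compounds shown, and "the series" means these compounds.

Measured compounds:
compound 1, `CC(C(=O)NCc1ccc(C(F)(F)F)nc1-c1ccccc1F)c1ccc(NS(C)(=O)=O)c(F)c1`, 63.3 nM
compound 2, `CC(C(=O)NCc1ccc(C(F)(F)F)nc1-c1ccco1)c1ccc(NS(C)(=O)=O)c(F)c1`, 5.8 nM

In an assay on CHO cells for antagonist activity at transient receptor potential cation channel subfamily V member 1 (Homo sapiens), read by FLIPR (on this read-out higher numbers stand for weaker inhibition and lower numbers for stronger inhibition), compound 1 gives 63.3 nM, the highest of the two numbers at hand; its nearest neighbour is compound 2, which in this assay gives 5.8 nM. Going by the values given here, the single step between them, an 11-fold lower number from compound 1 to compound 2 (1.04 log units; beyond the scatter), shows that the group on the aromatic carbon next to the ring nitrogen can move the number far.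

Compound 3, `CC(C(=O)NCc1ccc(C(F)(F)F)nc1C#Cc1ccccc1)c1ccc(NS(C)(=O)=O)c(F)c1`, is not yet measured. It differs from compound 1 in one place: 2-phenylethynyl in place of 2-fluorophenyl on an aromatic carbon. Among the compounds with values here, no measured step covers this particular exchange; the step from compound 1 to compound 2 only shows that this position is sensitive. A step of uncertain direction, possibly beyond the scatter, is therefore expected, leaning toward a lower number. Compound 3 is estimated at 35 nM, with a range from 7 nM to 180 nM, which corresponds to an expected 1.8-fold lower number from compound 1 to compound 3 (0.26 log units; within the scatter).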

Compound 3, inhibition constant: 0.8 nM
Estimate against measurement, compound 3: 44-fold (1.64 log units) above; measured number below the stated range.
By their numbers in this assay, from the lowest: compound 3; then compound 2; then compound 1.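

In this assay, the aromatic carbon next to the ring nitrogen proves far more responsive than the first pair suggested: 2-phenylethynyl in place of 2-fluorophenyl gives a 79-fold lower number from compound 1 to compound 3 (1.90 log units; beyond the scatter) and brings the number into a range neither ring-bearing compound reached. The same group also improves on furan-2-yl, with a 7.3-fold lower number from compound 2 to compound 3 (0.86 log units; beyond the scatter), so the furan of compound 2 does not mark the limit of this position, and a group with a triple bond gives the lowest number of the three. Nothing available here accounts for this gain.

The compounds shown leave open whether the gain belongs to the triple bond or to the phenyl at its end, since each exchange replaces the whole group. Going by these compounds, how an amine such as morpholine or a longer alkyl chain would read at this place also remains open.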